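This account rests on a few compounds, and the source may have more. Where it says the series, first, only, none or still open, it means among the compounds named here.

Of the compounds shown here, three built on one shared core have been measured in an assay on HEK293 cells for inhibition of Voltage-dependent T-type calcium channel subunit alpha-1G (Homo sapiens); a lower number here means a stronger inhibitor, a higher number a weaker inhibitor. Compound 1 `CC(C)(C)OC(=O)NCCCCCN1C(Nc2ccc(-c3ccccc3)cc2)=Nc2ccccc2C1CC(=O)NCc1ccccc1` gives 170 nM. Compound 2 `O=C(CC1c2ccccc2N=C(N2CCCCC2)N1c1ccccc1)NCc1ccc(NS(=O)(=O)c2ccc(F)cc2)cc1` gives 110 nM, which lies within the scatter of compound 1, so the two cannot be ordered. Compound 3 `COC(=O)CC1c2ccccc2N=C(NCCCCCNC(=O)OC(C)(C)C)N1c1ccc(-c2ccccc2)cc1` gives 680 nM, a number beyond the scatter above compound 1; compound 1 therefore stands second highest of the three. Compound 4 `COC(=O)CC1c2ccccc2N=C(Nc2ccc(-c3ccccc3)cc2)N1CCCCCNC(=O)OC(C)(C)C` awaits measurement and differs from compound 1 in one place: methoxy in place of benzylamino on a carbonyl carbon. Within the data shown here, no measured pair shows this exact change. Compound 3 also carries a methoxycarbonyl group and gives 680 nM. With that in view, the expected step is a 2.6-fold higher number from compound 1 to compound 4 (0.42 log units; beyond the scatter). Compound 4 is estimated at 450 nM, within a range of 150 nM to 1400 nM.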

Compound 4, half-maximal inhibitory concentration: 370 nM
Beside the measured number, compound 4's estimate is 1.2-fold (0.09 log units) above it, within the range that was stated.
By their numbers in this assay, from the lowest: compounds 2 and 1 (each within the scatter of the next); then compounds 4 and 3 (each within the scatter of the next).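

Among these compounds, replacing benzylamino with methoxy on this carbonyl carbon gives the first direct reading of this position: in this assay there is a 2.2-fold higher number from compound 1 to compound 4 (0.34 log units; beyond the scatter). The change is modest, and compound 4 remains measurable, so this pair does not show benzylamino to be essential for inhibition. No measurement here explains the step.

The compounds shown leave open which part of benzylamino matters. Methylamino, which keeps the amide hydrogen but lacks the ring, or a carboxylic acid at the same carbon would test this further.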